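From Dimethylsulfamoyl to 1-Cyanocyclopropyl: Estimating Compound 4

This account rests on a few compounds, and the source may have more. Where it says the series, first, only, none or still open, it means among the compounds named here.

Three compounds share one core. In an assay on Sf9 cells for inhibition of serine/threonine-protein kinase 4 (Homo sapiens), read by luminescence and ADP-Glo, with a stated time of 1 h, in the presence of a further agent that is not named here (on this read-out higher numbers stand for weaker inhibition and lower numbers for stronger inhibition), compound 1 `CN1C(=O)C(c2ccccc2F)N(C)c2nc(Nc3ccc(S(N)(=O)=O)cc3)ncc21` gives 75 nM, compound 2 `CN1C(=O)C(c2c(F)cccc2F)N(C)c2nc(Nc3ccc(S(=O)(=O)N(C)C)cc3)ncc21` gives 181 nM, and compound 3 `Cc1ccccc1C1C(=O)N(C)c2cnc(Nc3ccc(S(=O)(=O)N(C)C)cc3)nc2N1C` gives 219 nM, the highest of the three numbers; the step of a 1.2-fold higher number from compound 2 to compound 3 (0.08 log units; within the scatter) lies within the scatter, whereas compound 1 sits clearly lower.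

Compound 4 `Cc1ccccc1C1C(=O)N(C)c2cnc(Nc3ccc(C4(C#N)CC4)cc3)nc2N1C` differs from compound 3 in one place: 1-cyanocyclopropyl in place of dimethylsulfamoyl on an aromatic carbon. Among the measured compounds shown here, no measured step alters this position, because the only measured step, a 1.2-fold higher number from compound 2 to compound 3 (0.08 log units; within the scatter), changes the saturated ring carbon instead. Compounds 1 and 2 also differ there, but they differ in a second place too, so their numbers give no clean guide. The step of a 1.4-fold higher number from compound 3 to compound 4 (0.14 log units; within the scatter) is therefore expected to be small and of uncertain direction, and compound 4 is estimated at 300 nM, within 80 nM to 1200 nM.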

Compound 4, half-maximal inhibitory concentration: 256 nM
Compound 4: middle estimate off by 1.2-fold (0.07 log units), on the high side; the measured number falls inside the stated range.
By their numbers in this assay, from the lowest: compound 1; then compounds 2, 3 and 4 (each within the scatter of the next).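

In this assay, the first change shown at this position, on an aromatic carbon para to a large group, replaces dimethylsulfamoyl with 1-cyanocyclopropyl and gives a 1.2-fold higher number from compound 3 to compound 4 (0.07 log units; within the scatter). With the rest of the molecule held fixed, these two quite different groups therefore cannot be told apart on this read-out. No supporting measurement bears on this result.

As far as these compounds go, whether an amine or a carboxylic acid at this position would also read alike remains open. So does whether this exchange behaves the same with a different group on the saturated ring carbon.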